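Swapping a Methylpyrazole for an Acetylpyrazole on a Shared Core

A few compounds are considered here, and "the series" means these few. Any claim that something is new, unique, unknown or untested is made for them only; others in the source may bear on it.

Three compounds share one core and differ only in the aromatic ring at its far end: compound 1 `CNC(=O)N1CCCc2ccc(NC(=O)c3ccc(-c4ccncc4)cc3)cc21`, compound 2 `CNC(=O)N1CCCc2ccc(NC(=O)c3ccc(-c4cccnc4)cc3)cc21` and compound 3 `CNC(=O)N1CCCc2ccc(NC(=O)c3ccc(-c4cnn(C)c4)cc3)cc21`. In a functional assay on MV4-11 cells (Homo sapiens) for antiproliferative activity, with a stated time of 6 days, tested at 6.25 uM (a lower number here means a weaker effect, a higher number a stronger effect of the compound at the concentration tested), compound 1 gives 88.7%, compound 2 gives 92.1% and compound 3 gives 94.4%. Compound 3 stands at the top of these three numbers, yet the steps of a number 5.7 percentage points higher from compound 1 to compound 3 (within the scatter) and a number 2.3 percentage points higher from compound 2 to compound 3 (within the scatter), like a number 3.4 percentage points higher from compound 1 to compound 2 (within the scatter), all lie within the scatter, so the three cannot be told apart.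

Compound 4 `CNC(=O)N1CCCc2ccc(NC(=O)c3ccc(-c4ccn(C(C)=O)n4)cc3)cc21` carries 1-acetyl-1H-pyrazol-3-yl in place of 1-methyl-1H-pyrazol-4-yl on an aromatic carbon. Going by the values given here, no measured step touches an acetyl group, so the earlier steps bear only loosely; they show that changing this ring has so far moved nothing beyond the scatter. A step of a number 9.4 percentage points lower from compound 3 to compound 4 (within the scatter) is expected. Compound 4 is estimated at 85% in this assay, between 65% and 97%.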

Compound 4, a percentage reported as inhibition, at one concentration (the size of the read-out at that concentration, not a potency): 91.4%
Compound 4: the middle estimate sits 6.4 percentage points below what was measured; measured number inside the range.
By their numbers in this assay, from the lowest: compounds 1, 4, 2 and 3 (each within the scatter of the next).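

In this assay the 1-acetyl-1H-pyrazol-3-yl group, which adds a carbonyl and moves the ring's attachment point, cannot be told apart from the other three rings: the steps of a number 3 percentage points lower from compound 3 to compound 4 (within the scatter), a number 0.7 percentage points lower from compound 2 to compound 4 (within the scatter) and a number 2.7 percentage points higher from compound 1 to compound 4 (within the scatter) all stay within the scatter. This position therefore tolerates this larger group without a readable loss at the concentration tested. No available evidence accounts for this.

From the compounds shown here alone, all four compounds carry an aromatic ring here, so it remains open whether an amine or a carboxylic acid in its place would change the read-out. A single concentration also leaves any differences in potency among these compounds unresolved.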